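Trifluoromethyl for phenyl on an oxazole ketone

The compounds below may be only part of what the source reports. "The series", "measured", "known", "first", "only" and "open" are said of these compounds alone.

Measured compounds:
compound 1 `O=C(CCCCCCc1ccccc1)c1nc(-c2ccncc2)co1` — 1.6 nM
compound 2 `O=C(CCCCCCc1ccccc1)c1nc(-c2ccccc2)co1` — 65 nM

In an assay on isolated protein for inhibition of Fatty-acid amide hydrolase 1 (Rattus norvegicus) (on this read-out lower numbers stand for stronger inhibition and higher numbers for weaker inhibition), compound 1 gives 1.6 nM, and compound 2 gives 65 nM. Compound 2 thus stands highest of the two numbers; its nearest neighbour is compound 1, and the step of a 41-fold higher number from compound 1 to compound 2 (1.61 log units; beyond the scatter) is large and beyond the scatter. Compound 3 `O=C(CCCCCCc1ccccc1)c1nc(C(F)(F)F)co1` has not yet been measured. It differs from compound 2 in one place: trifluoromethyl in place of phenyl on an aromatic carbon. Among the compounds with values here, no measured step replaces a phenyl with a trifluoromethyl on the shared core; the only measured step, a 41-fold higher number from compound 1 to compound 2 (1.61 log units; beyond the scatter), shows that the group on this aromatic carbon can move the number by a great deal, and that the phenyl compound is the weaker of the two. For compound 3 a moderate step upward is expected, a 1.8-fold higher number from compound 2 to compound 3 (0.27 log units; within the scatter). Compound 3 is therefore expected at about 120 nM, within a range from 30 nM to 500 nM.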

Compound 3, inhibition constant: 3.7 nM
For compound 3 the middle estimate is 32-fold (1.51 log units) above the measured one, outside the stated range (below it).
By their numbers in this assay, from the lowest: compound 1; then compound 3; then compound 2.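

In this assay, the change from phenyl to trifluoromethyl gives an 18-fold lower number from compound 2 to compound 3 (1.24 log units; beyond the scatter) and so shows that a ring is not needed on this aromatic carbon for a low number. Trifluoromethyl also comes close to pyridin-4-yl without matching it, with a 2.3-fold higher number from compound 1 to compound 3 (0.36 log units; beyond the scatter) as a modest step that is still beyond the scatter, so compound 1 keeps the lowest number of the three. Among these three groups phenyl is therefore the one that stands apart, though nothing available explains why the groups rank in this order.

The compounds shown leave open whether a methyl, a chlorine or a nitrile on this carbon would give a number like that of compound 3. They also leave open whether the same order of groups would hold with a shorter chain on the ketone.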